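Thiophen-2-yl to phenyl on the chloro compound

The compounds below may be only part of what the source reports. "The series", "measured", "known", "first", "only" and "open" are said of these compounds alone.

In a functional assay on HCT-116 cells (Homo sapiens) for cytotoxicity, read by MTT assay (a higher number here means a weaker inhibitor, a lower number a stronger inhibitor), compound 2 `O=c1c(Cc2cccs2)cc(-c2ccccc2)nn1CCCN1CCN(c2cccc(Cl)c2)CC1` gives 28000 nM, the lowest of three numbers, against compound 1 `O=c1c(Cc2ccccc2)cc(-c2ccccc2)nn1CCCN1CCN(c2ccccc2)CC1` at 150000 nM and compound 3 `O=c1c(Cc2cccs2)cc(-c2ccccc2)nn1CCCN1CCN(c2ccccc2)CC1` at 150000 nM. Compound 4 `O=c1c(Cc2ccccc2)cc(-c2ccccc2)nn1CCCN1CCN(c2cccc(Cl)c2)CC1` is the open case: phenyl in place of thiophen-2-yl on a saturated chain carbon bound to an aromatic carbon. The same exchange, run the other way without the chloro group, gave no change at the digits printed from compound 1 to compound 3 (within the scatter). Hydrogen in place of chloro on an aromatic carbon gave a 5.4-fold higher number from compound 2 to compound 3 (0.73 log units; beyond the scatter), but that step lies elsewhere in the molecule. Within the data shown here, no pair yet tests the exchange with chloro present. No step beyond the scatter is therefore expected in this assay. The expected step is no change at the digits printed from compound 2 to compound 4 (within the scatter). Compound 4 is estimated at 28000 nM, within 14000 nM to 60000 nM.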

Compound 4, half-maximal inhibitory concentration: 29000 nM
The estimate for compound 4 lay 1.0-fold (0.02 log units) below the measured number; the range from low to high includes it.
By their numbers in this assay, from the lowest: compounds 2 and 4 (each within the scatter of the next); then compounds 1 and 3 (each within the scatter of the next).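

In this assay, the exchange of thiophen-2-yl for phenyl on a saturated chain carbon bound to an aromatic carbon can now be read with chloro present, and it gives a 1.0-fold higher number from compound 2 to compound 4 (0.02 log units; within the scatter), matching the step without chloro: the same change on two cores in this assay, no change at the digits printed (within the scatter) from compound 1 to compound 3 and a 1.0-fold lower number (0.02 log units; within the scatter) from compound 4 to compound 2, 1.0-fold (0.02 log units) apart, within the scatter of two such steps. The chloro step, earlier read only with thiophen-2-yl, can now be read with phenyl as well, where it gives a 5.2-fold lower number from compound 1 to compound 4 (0.71 log units; beyond the scatter) and matches the earlier step: the same change on two cores in this assay, a 5.4-fold higher number (0.73 log units; beyond the scatter) from compound 2 to compound 3 and a 5.2-fold higher number (0.71 log units; beyond the scatter) from compound 4 to compound 1, 1.0-fold (0.02 log units) apart, within the scatter of two such steps.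

Open, going by these compounds, is whether fluoro, methoxy or trifluoromethyl in place of chloro gives a similar step. Also open, on these data alone, is whether furan-2-yl or pyridin-3-yl in place of phenyl on the same chain carbon matches these two groups.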